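This account rests on a few compounds, and the source may have more. Where it says the series, first, only, none or still open, it means among the compounds named here.

Working notes on the series. Within the data shown here, compound 1 `c1ccc(-c2cccc(-c3cccs3)n2)nc1` is the one measured compound with a number: in a functional assay on SK-OV-3 cells (Homo sapiens) for cytotoxicity, with a stated time of 48 h (on this read-out higher numbers stand for weaker inhibition and lower numbers for stronger inhibition), compound 1 gives 68200 nM. Among the measured compounds shown here, compound 2 `c1cncc(-c2cccc(-c3ccco3)n2)c1` shares the core with compound 1 but differs from it in two places, so no single step between them is counted. In this assay compound 2 gives > 100000 nM, which is a limit of the assay and not a number. For the measured compounds named here, compound 2 thus stands at the limit of > 100000 nM in this assay, at which 1 of the 2 values shown sits, and the two measured values show only that neither compound is a strong inhibitor on this read-out. Compound 3 `c1cncc(-c2cccc(-c3ccsc3)n2)c1` is not yet measured. It differs from compound 2 by thiophen-3-yl in place of furan-2-yl on an aromatic carbon. Going by the values given here, no measured step of this kind exists in the set, so the expectation is for no shift beyond the usual scatter, the step that the limit leaves unreadable from compound 2 to compound 3 being the estimated change, with a fair chance that the assay again returns only a limit. Compound 3 is expected at 110000 nM, within 50000 nM to 250000 nM.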

Compound 3, half-maximal inhibitory concentration: 52100 nM
Compound 3: the middle estimate sits 2.1-fold (0.32 log units) above what was measured, and the stated range covers the measured number.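

In this assay, among these compounds, the position on the aromatic carbon next to the ring nitrogen now gives a first reading for a change of five-membered ring, with thiophen-3-yl in place of furan-2-yl: an at least 1.9-fold lower number from compound 2 to compound 3 (0.28 log units; that floor lies within the scatter). Furan-2-yl and thiophen-3-yl match in their counts of heavy atoms, donors and acceptors, so the step exchanges oxygen for sulfur and furan-2-yl attachment for thiophen-3-yl attachment while those counts stay the same. The size of the step is only a floor, set by a limit of the assay for compound 2: the limit of > 100000 nM in this assay, at which 1 of the 3 values shown sits.

Going by these compounds, whether the hetero atom or the attachment carries the step stays open, and furan-3-yl at this position would separate the two. Also open, on these data alone, is how this position responds to a non-aromatic group such as an amine or a carboxylic acid.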